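The source may report more compounds than this note shows. Statements on the series, on what has been measured and on what is new or still open speak of the compounds shown alone.

Measured so far in an assay on CHO cells for displacement of a labelled ligand from adenosine receptor A2b (Homo sapiens), read by scintillation counting, with a stated time of 75 min; a higher number here means a weaker inhibitor, a lower number a stronger inhibitor:
compound 1, `O=C(CCc1ccccc1)Nc1nc2ccccc2c(=O)s1`, 365 nM
compound 2, `O=C(CCCc1ccccc1)Nc1nc2ccc(Cl)cc2c(=O)s1`, > 1000 nM
compound 3, `COc1cccc(/C=C/C(=O)Nc2nc3ccccc3c(=O)s2)c1`, 679 nM

In this assay compound 1 gives 365 nM and compound 3 gives 679 nM; the two numbers lie within the usual scatter of each other, so no order between them can be read. Compound 2 is different in kind: its value of > 1000 nM is a limit of the assay, not a number, as the limit of > 1000 nM in this assay, at which 1 of the 3 values shown sits, records. Compound 1 therefore stands among the two proper numbers, with nothing beyond the scatter separating it from compound 3.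

The compound still to be measured is compound 4, `O=C(CCc1ccccc1Br)Nc1nc2ccccc2c(=O)s1`. It differs from compound 1 in one place: bromo in place of hydrogen on an aromatic carbon. Within the data shown here, no pair of measured compounds shares this change, so no measured step guides the expectation. The change is small in count and sits far from the shared core, and for this assay a step of no more than the scatter, in either direction, is expected. Compound 4 is estimated at 300 nM, in the range 120 nM to 800 nM, which is an expected step of a 1.2-fold lower number from compound 1 to compound 4 (0.09 log units; within the scatter).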

Compound 4, inhibition constant: > 1000 nM
Compound 4 gave a limit, no number; the forecaster's own chance of this, stated with the estimate: 10%; at least 3.3-fold (0.52 log units) between middle value and limit.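

Among these compounds, replacing hydrogen with bromo on this aromatic carbon, ortho to a large group, is the first single change to compound 1 that can be read in this assay, and it gives an at least 2.7-fold higher number from compound 1 to compound 4 (0.43 log units; beyond the scatter). This carbon of the phenyl is therefore not indifferent to substitution, since one added bromine atom is enough to carry the step beyond the scatter. Compound 4 stands at a limit of the assay, not at a number, so the full size of the step stays unknown: the limit of > 1000 nM in this assay, at which 2 of the 4 values shown sit.

The compounds shown leave open whether fluoro, methyl or methoxy on this same carbon would give a step of the same kind, and whether bromo on another carbon of the phenyl would do so. They also leave open how an amine at this place would read.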